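The compounds below may be only part of what the source reports. "The series", "measured", "known", "first", "only" and "open" are said of these compounds alone.

Three compounds have been measured in a physicochemical assay for acid dissociation:

Compound 1, `COc1ccccc1Oc1ccc2c(NCCCNCc3ccco3)ccnc2c1`, gives 9.28.
Compound 2, `COc1ccc(Oc2ccc3c(NCCCNCc4cccc(OC)c4O)ccnc3c2)cc1`, gives 9.28.
Compound 3, `COc1ccc(Oc2ccc3c(NCCCNCc4ccco4)ccnc3c2)cc1`, gives 9.28.

Compound 2 stands level with compound 1 and compound 3 at the digits shown; none of the three can be set apart from the others. The two single-site steps among them show the same picture: no change at the digits printed from compound 1 to compound 3 (within the scatter), and no change at the digits printed from compound 2 to compound 3 (within the scatter). A change at the oxygen-linked aryl group and a change at the amine-linked group both left the read-out where it was.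

Compound 4, `COc1ccc(-c2ccc3c(NCCCNCc4cccc(OC)c4O)ccnc3c2)cc1`, has not yet been measured. It differs from compound 2 in one place: 4-methoxyphenyl in place of 4-methoxyphenoxy on an aromatic carbon. For the measured compounds named here, no measured step makes exactly this change; the nearest precedent is the step from compound 1 to compound 3, which reshaped the same oxygen-linked part of the molecule without any shift beyond the scatter. On that basis, compound 4 is expected to give a step of no change at the digits printed from compound 2 to compound 4 (within the scatter), that is, none beyond the scatter. The estimate for compound 4 is therefore 9.28, between 8.9 and 9.7.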

Compound 4, acid dissociation constant: 9.47
Compound 4: the middle estimate sits 0.19 log units below what was measured; the measured number falls inside the stated range.
By their numbers in this assay, from the lowest: compounds 1, 2, 3 and 4 (each within the scatter of the next).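

Compound 1, compound 2 and compound 3 all keep an oxygen link to their methoxy-bearing aryl group, so they could not show what happens when that link goes. Here, 4-methoxyphenyl replaces 4-methoxyphenoxy on an aromatic carbon of the shared core, and this assay shows a number 0.19 log units higher from compound 2 to compound 4 (within the scatter) and so the oxygen link can be removed at this position with no shift that stands clear of repeat measurements. No supporting measurement bears on this result.

The compounds shown leave open whether a quite different group at this aromatic carbon, such as an amine or a carboxylic acid, would also leave the number in place. They also leave open whether the same swap would give a similar result with a longer saturated chain in the molecule.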